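Trading Ethoxy for Two Bromines on the Hydroxyphenyl Group

The source may hold more compounds than are shown below. What is called first, only, known or untested is meant among the compounds shown, and "the series" means these compounds.

Within the data shown here, in a functional assay on SMMC-7721 cells (Homo sapiens) for antiproliferative activity, read by MTT assay, with a stated time of 72 h (a higher number here means a weaker inhibitor, a lower number a stronger inhibitor), compound 2 `CCOc1cccc(/C=N/NC(=O)c2cccc(S(=O)(=O)N3CCOCC3)c2)c1O` gives 6990 nM, the only true number so far. Compound 1 `O=C(N/N=C/c1ccco1)c1cccc(S(=O)(=O)N2CCOCC2)c1` is reported as a limit, > 100000 nM.

Compound 3 `O=C(N/N=C/c1cc(Br)cc(Br)c1O)c1cccc(S(=O)(=O)N2CCOCC2)c1` carries 3,5-dibromo-2-hydroxyphenyl in place of 3-ethoxy-2-hydroxyphenyl on a carbon with a double bond to nitrogen. Among the measured compounds shown here, one measured step bears on this change, and only indirectly: an at least 14-fold lower number from compound 1 to compound 2 (1.15 log units; beyond the scatter), which is large. From the compounds shown here alone, that step starts from compound 1 at the limit of > 100000 nM in this assay, at which 1 of the 2 values shown sits, so its full size remains open. It replaced furan-2-yl with 3-ethoxy-2-hydroxyphenyl, and it cannot separate the contributions of the ethoxy and hydroxy groups. For the measured compounds named here, no measured step shows what bromine does here.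

The 2-hydroxyphenyl is retained in both compounds. The large gain seen in an at least 14-fold lower number from compound 1 to compound 2 (1.15 log units; beyond the scatter) is not expected to be lost, and no clear shift in either direction is expected. The estimated change is a 1.3-fold lower number from compound 2 to compound 3 (0.10 log units; within the scatter), with no step beyond the scatter expected. For compound 3 the estimate is 5500 nM, with an expected range of 1500 nM to 20000 nM.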

Compound 3, half-maximal inhibitory concentration: 7310 nM
For compound 3 the middle estimate is 1.3-fold (0.12 log units) below the measured one; the measured number falls inside the stated range.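

In this assay, 3,5-dibromo-2-hydroxyphenyl in place of 3-ethoxy-2-hydroxyphenyl on the carbon with a double bond to nitrogen gives a 1.0-fold higher number from compound 2 to compound 3 (0.02 log units; within the scatter), so the two groups cannot be told apart here, although the ethoxy group and the two bromines have little in common. The large gain over furan-2-yl therefore does not rest on the ethoxy group alone, since a second substituted 2-hydroxyphenyl group also gives it, with an at least 13-fold lower number from compound 1 to compound 3 (1.13 log units; beyond the scatter). From the compounds shown here alone, the full size of that gain stays open because compound 1 stands at a limit of the assay, not at a number: the limit of > 100000 nM in this assay, at which 1 of the 3 values shown sits.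

The compounds shown leave open what the hydroxy group itself contributes, and whether a plain phenyl or a 2-methoxyphenyl group on the same carbon would keep the level shared by compound 2 and compound 3. They also do not tell whether a single bromine, a chlorine or an amine on the hydroxyphenyl group would produce a step beyond the scatter in this assay.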